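A Carbocycle Replaces the Oxolane Ether

A few compounds are considered here, and "the series" means these few. Any claim that something is new, unique, unknown or untested is made for them only; others in the source may bear on it.

Of the compounds shown here, three have been measured so far in an assay on isolated protein for inhibition of ATP-dependent RNA helicase DDX3X (Homo sapiens), read by FRET, with stated times of 30 s and 40 min; on this read-out higher numbers stand for weaker inhibition and lower numbers for stronger inhibition. Compound 1 `O=C(Nc1ccc(-n2cc(CCO[C@H]3O[C@@H](CO)[C@H](O)[C@@H]3O)nn2)cc1)Nc1ccccc1C(F)(F)F` gave "not active" (no number reported). Compound 2 `CCOC(=O)CCc1cn(-c2ccc(NC(=O)Nc3ccccc3C(F)(F)F)cc2)nn1` reached 2020 nM, a clearly weaker result than compound 3. Compound 3 `CCCCc1cn(-c2ccc(NC(=O)Nc3cc(OC4CCOC4)ccc3C)cc2)nn1` stands at 100 nM, the lowest of the two numbers reported, with the gap to compound 2 lying beyond the usual scatter of this assay.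

The next compound keeps the whole skeleton of compound 3 and alters only one substituent: compound 4 `CCCCc1cn(-c2ccc(NC(=O)Nc3cc(OC4CCCC4)ccc3C)cc2)nn1` differs from compound 3 by cyclopentyl in place of oxolan-3-yl on an oxygen on an aromatic ring. Within the data shown here, no comparable pair of measured compounds is available, so the size of this step cannot be read from the data already in hand. Among the measured compounds shown here, with only a single oxygen-for-carbon swap inside a five-membered ring that sits at the far edge of the molecule, the expectation is a small shift, if any, not clearly beyond the scatter. Compound 4 is therefore expected to land near compound 3, at an estimated 120 nM with a range from 40 nM to 400 nM, which means an expected step of a 1.2-fold higher number from compound 3 to compound 4 (0.08 log units; within the scatter).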

Compound 4, half-maximal inhibitory concentration: 140 nM
Beside the measured number, compound 4's estimate is 1.2-fold (0.07 log units) below it; the range from low to high includes it.
By their numbers in this assay, from the lowest: compounds 3 and 4 (each within the scatter of the next); then compound 2.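

In this assay, among these compounds, the exchange of (oxolan-3-yl)oxy for cyclopentyloxy gives a 1.4-fold higher number from compound 3 to compound 4 (0.15 log units; within the scatter), the first direct comparison at this place, on an oxygen on an aromatic ring. Compound 3 and compound 4 therefore stand level, and the hydrogen-bond acceptor counted in the oxolan-3-yl ring, absent from cyclopentyl, can go without a shift beyond the scatter. No measurement at hand offers an explanation for this result.

The compounds shown leave open how this oxygen would tolerate a group of another kind, such as a piperidine ring, a carboxylic acid or a longer chain. They also leave open whether the same exchange would read alike with a group other than the butyl chain on the shared core.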